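Shifting the methoxy group on the aryl ring of compound 1

A few compounds are considered here, and "the series" means these few. Any claim that something is new, unique, unknown or untested is made for them only; others in the source may bear on it.

Going by the values given here, compound 1 `COc1cccc(/C=C/C(=O)/C=C/c2ccc(OCc3cn(CCOc4cc(=O)oc5ccccc45)nn3)c(OC)c2)c1` is the stronger of the two compounds measured so far. In a functional assay on HCT-116 cells (Homo sapiens) for inhibition, read by sulforhodamine B assay, with a stated time of 48 h, tested at 50 uM (on this read-out higher numbers stand for more inhibition of growth at the one concentration tested and lower numbers for less inhibition of growth), compound 1 gives 70%. Compound 2 `COc1ccc(/C=C/C(=O)/C=C/c2ccc(OCc3cn(CCCCOc4cc(=O)oc5ccccc45)nn3)c(OC)c2)cc1` differs from compound 1 in several places. In this assay compound 2 gives 40%. The gap between the two values lies beyond the scatter, so compound 1 stands clearly highest of the two numbers in hand. Among the compounds with values here, no single-point step between measured compounds exists in this set, so nothing is yet known about how a change on the aryl ring alone moves the read-out.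

Compound 3 `COc1ccccc1/C=C/C(=O)/C=C/c1ccc(OCc2cn(CCOc3cc(=O)oc4ccccc34)nn2)c(OC)c1` is the next candidate. It differs from compound 1 by 2-methoxyphenyl in place of 3-methoxyphenyl on a double-bonded chain carbon bound to a double-bonded chain carbon. Within the data shown here, with no comparable step measured, the expected step of a number 10 percentage points lower from compound 1 to compound 3 (within the scatter) is small, downward if anything, and not beyond the scatter. Compound 3 is therefore estimated to give about 60% in this assay, in a range from 35% to 85%.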

Compound 3, percent growth inhibition at one concentration: 70%
Compound 3: middle estimate off by 10 percentage points, on the low side, and the stated range covers the measured number.
By their numbers in this assay, from the lowest: compound 2; then compounds 1 and 3 (each within the scatter of the next).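

In this assay, going by these compounds alone, 2-methoxyphenyl in place of 3-methoxyphenyl on a double-bonded chain carbon bound to a double-bonded chain carbon gives no change at the digits printed from compound 1 to compound 3 (within the scatter), the first step that changes one place only. The read-out at this single concentration therefore does not separate these two methoxyphenyl groups at this place. Nothing measured here explains why the two compounds read alike.

From the compounds shown here alone, it remains open whether the read-out would hold with a different group on the phenyl ring, such as a hydroxy group, a chlorine atom or a dimethylamino group in place of methoxy. A single-concentration read-out also leaves open whether compound 1 and compound 3 would stay together across a full concentration range.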